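Propargyl thioether variant of the pyrazolylamino series

The source may report more compounds than this note shows. Statements on the series, on what has been measured and on what is new or still open speak of the compounds shown alone.

Among the compounds with values here, compound 2 `Cc1cc(Nc2cc(-c3ccccc3)[nH]n2)n2nc(SCc3ccccc3Br)nc2n1` gives 3020 nM in a functional assay on MCF7 cells (Homo sapiens) for inhibition, read by MTT assay, with a stated time of 72 h (on this read-out higher numbers stand for weaker inhibition and lower numbers for stronger inhibition), the lowest of the two numbers so far; the nearest, compound 1 `Cc1cc(Nc2cc(-c3ccccc3)[nH]n2)n2nc(SCc3ccc([N+](=O)[O-])cc3)nc2n1`, gives 5060 nM. Within the data shown here, the only step available, a 1.7-fold lower number from compound 1 to compound 2 (0.22 log units; within the scatter), exchanges one aryl for another and stays within the scatter. Compound 3 `C#CCSc1nc2nc(C)cc(Nc3cc(-c4ccccc4)[nH]n3)n2n1` differs from compound 2 by ethynyl in place of 2-bromophenyl on a saturated chain carbon bound to a sulfur. Among the measured compounds shown here, no step among the measured compounds tests loss of the ring, so nothing supports a step beyond the scatter in either direction. For compound 3 in this assay the expected value is 4000 nM, range 1500 nM to 12000 nM, meaning an expected step of a 1.3-fold higher number from compound 2 to compound 3 (0.12 log units; within the scatter).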

Compound 3, half-maximal inhibitory concentration: 21800 nM
Compound 3: the middle estimate sits 5.5-fold (0.74 log units) below what was measured; measured number above the stated range.
By their numbers in this assay, from the lowest: compounds 2 and 1 (each within the scatter of the next); then compound 3.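

Ethynyl in place of an aryl group on this saturated chain carbon bound to a sulfur gives the first change here beyond the scatter in this assay: a 7.2-fold higher number from compound 2 to compound 3 (0.86 log units; beyond the scatter), and a 4.3-fold higher number from compound 1 to compound 3 (0.63 log units; beyond the scatter). Both aryl compounds therefore give lower numbers than the ethynyl compound, although the two aryl groups themselves remain within the scatter of each other. Nothing available explains this shift.

As far as these compounds go, it remains open whether the aromatic ring or simply a larger group accounts for the difference. A cyclohexyl group or a longer alkyl chain at this place would separate the two.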